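This account rests on a few compounds, and the source may have more. Where it says the series, first, only, none or still open, it means among the compounds named here.

Measured so far:
Compound 1, `O=C1c2ccc(Cl)cc2CN1c1cccnc1`, 179 nM
Compound 2, `CCC1c2cc(Cl)ccc2C(=O)N1c1cccnc1`, 121 nM
Compound 3, `CCC(=O)N[C@@H]1CCCc2c1cncc2N1Cc2cc(Cl)ccc2C1=O`, 28 nM

In an assay on cells for inhibition of cytochrome P450 11B2, mitochondrial (Homo sapiens), read by HTRF (a higher number here means a weaker inhibitor, a lower number a stronger inhibitor), compound 1 gives 179 nM. Compound 2 carries ethyl in place of hydrogen on a saturated ring carbon, and the step of a 1.5-fold lower number from compound 1 to compound 2 (0.17 log units; within the scatter) is small. Compound 3 has a different core; how its core differs from that of compound 1 is not broken down here, but in this assay compound 3 gives 28 nM, the lowest of the three numbers.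

Compound 4, `CCC(=O)N[C@@H]1CCCc2c1cncc2N1C(=O)c2ccc(Cl)cc2[C@H]1CC`, is not yet measured. It differs from compound 3 by ethyl in place of hydrogen on a saturated ring carbon. This is the same kind of change as that from compound 1 to compound 2; the surroundings differ only in that the ring atom beside the altered carbon bears a large group in compound 3 rather than a pyridin-3-yl group. Because a 1.5-fold lower number from compound 1 to compound 2 (0.17 log units; within the scatter) was within the scatter, a similarly small step a 1.3-fold lower number from compound 3 to compound 4 (0.10 log units; within the scatter) is expected. Compound 4 is estimated at 22 nM, between 9 nM and 55 nM.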

Compound 4, half-maximal inhibitory concentration: 90 nM
The estimate for compound 4 lay 4.1-fold (0.61 log units) below the measured number; measured number outside the range, above it.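

In this assay, ethyl in place of hydrogen on a saturated ring carbon gives a 3.2-fold higher number from compound 3 to compound 4 (0.51 log units; beyond the scatter), so the change does not carry over unchanged from one core to the other: the same change on two cores in this assay, a 1.5-fold lower number (0.17 log units; within the scatter) from compound 1 to compound 2 and a 3.2-fold higher number (0.51 log units; beyond the scatter) from compound 3 to compound 4, 4.8-fold (0.68 log units) apart, beyond the scatter of two such steps

The small step on the core of compound 1 is therefore a poor guide to the step on the core of compound 3. For the compounds shown here, with only one pair on each core, this does not show which difference between the cores matters, or how the change would behave on a third core.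

Going by these compounds, it remains open whether a methyl or a longer chain at this carbon would follow the ethyl on the core of compound 3. Also open, on these data alone, is how the opposite arrangement of the ethyl at that carbon would compare.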